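Carboxylic acid ester hydrolysis and halogen swap in aminothiazole series

This account rests on a few compounds, and the source may have more. Where it says the series, first, only, none or still open, it means among the compounds named here.

Compound 1 `CCOC(=O)c1sc(-c2cccc(NC(=O)c3ccc(Cl)cc3)c2)nc1Nc1ccc(N2CCN(C)CC2)cc1` carries an ethyl ester; in a functional assay on Raji cells (Homo sapiens) for antiproliferative activity, read by CCK-8 assay, with a stated time of 72 h, tested at 40 uM (on this read-out higher numbers stand for more inhibition at the one concentration tested (going by the name of the read-out) and lower numbers for less inhibition), compound 1 gives 24.3%. Compound 2 `CCOC(=O)c1sc(-c2cccc(NC(=O)c3ccc(F)c(Cl)c3)c2)nc1Nc1ccc(N2CCN(C)CC2)cc1` differs from it only by 3-chloro-4-fluorophenyl in place of 4-chlorophenyl on a carbonyl carbon, and in this assay compound 2 gives 20.7%; the step of a number 3.6 percentage points lower from compound 1 to compound 2 (within the scatter) is within the scatter, so the two values cannot be ordered. Compound 3 `CN1CCN(c2ccc(Nc3nc(-c4cccc(NC(=O)c5ccc(Cl)cc5)c4)sc3C(=O)O)cc2)CC1` differs from compound 1 by hydrogen in place of ethyl on an oxygen next to a carbonyl group, and in this assay compound 3 gives 90.9%; the step of a number 66.6 percentage points higher from compound 1 to compound 3 (beyond the scatter) is large and the value of compound 3 stands furthest from compound 2 among the three numbers.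

Compound 4 `CN1CCN(c2ccc(Nc3nc(-c4cccc(NC(=O)c5ccc(F)c(Cl)c5)c4)sc3C(=O)O)cc2)CC1` is not yet measured. Among the measured compounds shown here, it differs from compound 3 by 3-chloro-4-fluorophenyl in place of 4-chlorophenyl on a carbonyl carbon, which is the same change as the one seen from compound 1 to compound 2, at a place that reads the same word for word. The cores of the two pairs differ by hydrogen in place of ethyl on an oxygen next to a carbonyl group.

The step from compound 3 to compound 4 is expected to be a number 2.9 percentage points lower from compound 3 to compound 4 (within the scatter), resting on the earlier step of a number 3.6 percentage points lower from compound 1 to compound 2 (within the scatter) being within the scatter. Compound 4 is thus estimated at 88%, between 72% and 97%.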

Compound 4, a percentage reported as inhibition, at one concentration (the size of the read-out at that concentration, not a potency): 87.9%
Compound 4: the middle estimate sits 0.1 percentage points above what was measured; low and high end bracket the measured number.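

In this assay, the change to 3-chloro-4-fluorophenyl produces no readable step on the carboxylic acid core, a number 3 percentage points lower from compound 3 to compound 4 (within the scatter), and the result matches the one on the ethyl ester core: the same change on two cores in this assay, a number 3.6 percentage points lower (within the scatter) from compound 1 to compound 2 and a number 3 percentage points lower (within the scatter) from compound 3 to compound 4, 0.6 percentage points apart, within the scatter of two such steps. The change from ethyl ester to carboxylic acid also carries over when the 3-chloro-4-fluorophenyl group is present, a number 67.2 percentage points higher from compound 2 to compound 4 (beyond the scatter), and its size matches the step seen with 4-chlorophenyl: the same change on two cores in this assay, a number 66.6 percentage points higher (beyond the scatter) from compound 1 to compound 3 and a number 67.2 percentage points higher (beyond the scatter) from compound 2 to compound 4, 0.6 percentage points apart, within the scatter of two such steps. These four compounds show the two changes combining independently at this one concentration, but they give no potency, do not allow compound 3 and compound 4 to be ordered, and do not show that the pattern would hold for other substituents or cores.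

As far as these compounds go, it remains open whether a primary amide, a methyl ester or a tetrazole in place of the carboxylic acid would give a high or a low inhibition value. From the compounds shown here alone, it is also open whether a methoxy or trifluoromethyl group on the phenyl ring of the amide would leave the read-out as unchanged as the halogen swap did.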